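The compounds below may be only part of what the source reports. "The series", "measured", "known", "first", "only" and "open" are said of these compounds alone.

Compound 1 `CC1=C(/C=C/C(=O)/C=C/c2ccc(F)cc2)C(C)(C)CCC1` is the reference point of this series. For the measured compounds named here, in a functional assay on IMR-32 cells (Homo sapiens) for cytotoxicity, read by sulforhodamine B assay, with a stated time of 48 h (a higher number here means a weaker inhibitor, a lower number a stronger inhibitor), compound 1 gives 7400 nM, the lowest number among the three compounds measured so far. Its nearest neighbour is compound 3 `CC1=C(/C=C/C(=O)/C=C/c2ccccc2[N+](=O)[O-])C(C)(C)CCC1`, which in this assay gives 13500 nM, a gap that lies within the scatter of repeated measurements, so the two cannot be ranked against each other. Going by the values given here, compound 2 `COc1ccc(/C=C/C(=O)/C=C/C2=C(C)CCCC2(C)C)cc1` gives 23900 nM in this assay, and the single comparison between compounds that differ in one place is a 3.2-fold higher number from compound 1 to compound 2 (0.51 log units; beyond the scatter).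

The step from compound 1 to compound 4 `CC1=C(/C=C/C(=O)/C=C/c2cccnc2)C(C)(C)CCC1` is pyridin-3-yl in place of 4-fluorophenyl on a double-bonded chain carbon bound to a double-bonded chain carbon. Among the compounds with values here, no measured pair exchanges the aromatic ring of this end of the chain for a ring with a hetero atom, so the only guidance is the change at the same end of the molecule, which gave a modest shift. A step of comparable size, or none beyond the scatter, is therefore expected in this assay, with the direction uncertain but more likely toward a higher number, as seen for compound 2.

Compound 4 is expected to give 11000 nM in this assay, within a range from 4500 nM to 27000 nM, which would mean a step of a 1.5-fold higher number from compound 1 to compound 4 (0.17 log units; within the scatter).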

Compound 4, half-maximal inhibitory concentration: 25300 nM
Beside the measured number, compound 4's estimate is 2.3-fold (0.36 log units) below it; the range from low to high includes it.
By their numbers in this assay, from the lowest: compounds 1, 3, 2 and 4 (each within the scatter of the next, the first and the last beyond it).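

Exchanging 4-fluorophenyl for pyridin-3-yl on a double-bonded chain carbon bound to a double-bonded chain carbon gives, in this assay, a 3.4-fold higher number from compound 1 to compound 4 (0.53 log units; beyond the scatter). For the compounds shown here, until now the only readable change at this end of the molecule was a swap of one substituent on an aromatic carbon, whereas this step shows that replacing the whole aromatic ring with one carrying a hetero atom also moves the number beyond the scatter, and in the same direction as a 3.2-fold higher number from compound 1 to compound 2 (0.51 log units; beyond the scatter). No measurement shown here bears on what lies behind this step.

The compounds shown do not separate the loss of the fluoro group from the entry of the ring nitrogen, and an unsubstituted phenyl at this place would be needed to divide the step between those two parts. They also leave open whether the nitrogen's place in the ring matters, as pyridin-2-yl or pyridin-4-yl could show, and whether an amine or a carboxylic acid on the aromatic ring would keep the number near that of compound 1 at 7400 nM.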